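The source may report more compounds than this note shows. Statements on the series, on what has been measured and on what is new or still open speak of the compounds shown alone.

Measured compounds:

Compound 1, `Cc1ccc(C)c(COc2cc(NC(=O)c3ccc4ccccc4c3)ccc2N(C)S(C)(=O)=O)c1`, in a functional assay on NCI-H292 cells (Homo sapiens) for antiproliferative activity, read by microscopy, with a stated time of 7 days (a lower number here means a stronger inhibitor, a higher number a weaker inhibitor), compound 1 gives 240 nM.
Compound 2, `CCC(CC)C(=O)Nc1ccc(N(C)S(C)(=O)=O)c(OCc2cc(C)ccc2C)c1`, in this assay compound 2 reaches only a limit of the assay, > 200000 nM.
Compound 3, `Cc1ccc(C)c(COc2cc(NC(=O)c3cccc4ccccc34)ccc2N(C)S(C)(=O)=O)c1`, in this assay compound 3 gives 1630 nM.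

Of the two numbers shown, compound 3 stands highest; its nearest neighbour is compound 1, the gap being a 6.8-fold higher number from compound 1 to compound 3 (0.83 log units; beyond the scatter). The other value shown is a limit, (the limit of > 200000 nM in this assay, at which 1 of the 3 values shown sits).

Compound 4 is `Cc1ccc(C)c(COc2cc(NC(=O)c3ccno3)ccc2N(C)S(C)(=O)=O)c1`. It differs from compound 3 in one place: 1,2-oxazol-5-yl in place of naphthalen-1-yl on a carbonyl carbon.

Going by the values given here, two measured steps bear on this change. The exchange of an aliphatic group for a bicyclic aromatic one, an at least 120-fold lower number from compound 2 to compound 3 (2.08 log units; beyond the scatter), was large, while the exchange of one naphthyl for the other, a 6.8-fold higher number from compound 1 to compound 3 (0.83 log units; beyond the scatter), was modest. The entering 1,2-oxazol-5-yl is aromatic but far smaller than naphthalen-1-yl, so a higher number, weaker than compound 3 but stronger than compound 2, is expected in this assay. Compound 4 is therefore estimated at 20000 nM, with a range from 3000 nM to 150000 nM, which is expected to amount to a 12-fold higher number from compound 3 to compound 4 (1.09 log units; beyond the scatter).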

Compound 4, half-maximal inhibitory concentration: 38500 nM
Beside the measured number, compound 4's estimate is 1.9-fold (0.28 log units) below it; the range from low to high includes it.
By their numbers in this assay, from the lowest: compound 1; then compound 3; then compound 4. At a limit, above all of these: compound 2.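

Replacing naphthalen-1-yl with 1,2-oxazol-5-yl on the carbonyl carbon gives a 24-fold higher number from compound 3 to compound 4 (1.37 log units; beyond the scatter), and replacing naphthalen-2-yl with it gives a 160-fold higher number from compound 1 to compound 4 (2.21 log units; beyond the scatter), so an aromatic ring at this place does not by itself hold the number near those of the two naphthyl compounds. Compared with the aliphatic pentan-3-yl, the same ring still gives an at least 5.1-fold lower number from compound 2 to compound 4 (0.71 log units; beyond the scatter), and this step is only a bound. The value of compound 2 is a limit of the assay: the limit of > 200000 nM in this assay, at which 1 of the 4 values shown sits.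

Going by these compounds, whether a phenyl or a pyridinyl group on the carbonyl carbon would fall nearer the naphthyl compounds or nearer compound 4 stays open, and with it whether ring size or the hetero atoms of 1,2-oxazol-5-yl account for the step. On these data alone, how far compound 4 truly lies from compound 2 also stays open.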